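The source may hold more compounds than are shown below. What is called first, only, known or untested is meant among the compounds shown, and "the series" means these compounds.

Measured so far in a functional assay on MCF7 cells (Homo sapiens) for antiproliferative activity, read by MTT assay, with a stated time of 48 h; a lower number here means a stronger inhibitor, a higher number a weaker inhibitor:

- compound 1 `COc1cccc(C(=O)Nc2cccc(/C=C/C(=O)c3nc4ccccc4[nH]3)c2)c1` gives 17800 nM
- compound 2 `O=C(/C=C/c1cccc(NS(=O)(=O)c2ccccc2Cl)c1)c1nc2ccccc2[nH]1` gives 4280 nM
- compound 3 `O=C(/C=C/c1cccc(NS(=O)(=O)c2ccc(Cl)cc2)c1)c1nc2ccccc2[nH]1` gives 3820 nM

Compound 3 holds the lowest number of the three; its gap to compound 2 is within the scatter, and only the gap to compound 1 is beyond it. The two sulfonyl compounds sit apart from compound 1: a 4.2-fold lower number from compound 1 to compound 2 (0.62 log units; beyond the scatter) and a 4.7-fold lower number from compound 1 to compound 3 (0.67 log units; beyond the scatter) are both modest, while a 1.1-fold lower number from compound 2 to compound 3 (0.05 log units; within the scatter) shows that exchanging one chlorophenyl for the other made no difference beyond the scatter.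

Compound 4 `Cc1cccc(S(=O)(=O)Nc2cccc(/C=C/C(=O)c3nc4ccccc4[nH]3)c2)c1` keeps the sulfonamide and changes only the aryl group on it: 3-methylphenyl in place of 4-chlorophenyl on a sulfonyl sulfur. Among the measured compounds shown here, no measured pair exchanges a chlorine for a methyl, so the only step that bears on it is the one between the two chlorophenyl sulfonamides, which stayed within the scatter. On that basis a step within the scatter is expected, a 1.2-fold higher number from compound 3 to compound 4 (0.07 log units; within the scatter), with no resolved direction. Compound 4 is estimated at 4500 nM in this assay, with a range of 1800 nM to 11000 nM.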

Compound 4, half-maximal inhibitory concentration: 886 nM
For compound 4 the middle estimate is 5.1-fold (0.71 log units) above the measured one, outside the stated range (below it).
By their numbers in this assay, from the lowest: compound 4; then compounds 3 and 2 (each within the scatter of the next); then compound 1.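

In this assay, the aryl group on the sulfonyl sulfur now makes a difference beyond the scatter: 3-methylphenyl in place of 4-chlorophenyl gives a clear step (a 4.3-fold lower number from compound 3 to compound 4 (0.63 log units; beyond the scatter)), and 3-methylphenyl in place of 2-chlorophenyl gives one of similar size (a 4.8-fold lower number from compound 2 to compound 4 (0.68 log units; beyond the scatter)), whereas the two chlorophenyl groups had stayed within the scatter of each other. Among the compounds shown here, the comparison with the carbonyl compound also widens, with (3-methylphenyl)sulfonyl in place of (3-methoxyphenyl)carbonyl on the nitrogen giving the only large step here (a 20-fold lower number from compound 1 to compound 4 (1.30 log units; beyond the scatter)). No measurement at hand accounts for the gain at the sulfonyl sulfur.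

The compounds shown cannot separate the methyl group from its ring position, a question that 3-chlorophenyl and 4-methylphenyl would address. Going by these compounds, how far the gain extends to a larger group, such as 3-ethylphenyl, or to an amine on the ring also remains open.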